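Phenyl in place of naphthalen-2-yl on an aromatic nitrogen

This account rests on a few compounds, and the source may have more. Where it says the series, first, only, none or still open, it means among the compounds named here.

Measured in a functional assay on A549 cells (Homo sapiens) for antiproliferative activity, with a stated time of 5 days; a lower number here means a stronger inhibitor, a higher number a weaker inhibitor:
Compound 1 `COc1ccc(-n2nc(-c3ccc4ccccc4c3)nc2N2C(=O)COC23C=CC(=O)C=C3)cc1` gives 260 nM in this series
Compound 2 `CC1OC2(C=CC(=O)C=C2)N(c2nc(-c3ccc4ccccc4c3)nn2-c2ccc3ccccc3c2)C1=O` gives 300 nM in this series

Compound 2 stands level with compound 1 on these numbers, as their two values lie within the scatter of each other. Among the compounds with values here, with only two measured compounds, no ranking or trend can be drawn. Within the data shown here, the two also differ in more than one place, so no single-change step is available to calibrate the next comparison.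

The next compound is compound 3 `CC1OC2(C=CC(=O)C=C2)N(c2nc(-c3ccc4ccccc4c3)nn2-c2ccccc2)C1=O`, which differs from compound 2 at one place: phenyl in place of naphthalen-2-yl on an aromatic nitrogen. Among the measured compounds shown here, the only guide is indirect. Compound 1 also carries a single aromatic ring on that nitrogen and gives 260 nM in this assay, though it has other differences from compound 3. No change beyond the scatter is expected (no change at the digits printed from compound 2 to compound 3 (within the scatter)), and the range is left wide in either direction. The estimated value for compound 3 is 300 nM ( range 120 nM to 750 nM).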

Compound 3, half-maximal inhibitory concentration: 310 nM
For compound 3 the middle estimate is 1.0-fold (0.01 log units) below the measured one, within the range that was stated.
By their numbers in this assay, from the lowest: compounds 1, 2 and 3 (each within the scatter of the next).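

In this assay, phenyl in place of naphthalen-2-yl on the aromatic nitrogen gives a 1.0-fold higher number from compound 2 to compound 3 (0.01 log units; within the scatter), the first single-change step available in this series. This position therefore accepts one six-membered aromatic ring of carbon only as well as two, and going from 10 heavy atoms to 6 in this group leaves the antiproliferative read-out within the scatter on this core. Nothing available explains this result.

The compounds shown leave open whether this level read-out extends beyond groups made only of aromatic carbon, for example to a pyridine ring, a phenyl carrying a carboxylic acid or an amine, or a simple alkyl chain on the same nitrogen. They also leave open whether phenyl and naphthalen-2-yl would stay level on this nitrogen if the naphthalen-2-yl group on the ring atom two ring bonds away were replaced by another group.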